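Ring size on the amino group and cell tolerance

The compounds below may be only part of what the source reports. "The series", "measured", "known", "first", "only" and "open" are said of these compounds alone.

Compound 1 `CCCCSc1nc(N)nc2c1ncn2/C=C1/CC1(CO)CO` in an ADME assay on MOLT-3 cells (Homo sapiens) for cytotoxicity, with a stated time of 7 days (a higher number here means that more compound is tolerated, a lower number that less compound is tolerated), gives > 20000 nM, a limit of the assay.
Compound 2 `Nc1nc(NC2CC2)c2ncn(/C=C3/CC3(CO)CO)c2n1` in this assay gives > 20000 nM, again a limit.
Compound 3 `CCCCNc1nc(N)nc2c1ncn2/C=C1/CC1(CO)CO` in this assay gives > 20000 nM, also a limit.

Compound 2 therefore stands where every measured compound stands: at the limit, with no number of its own, a situation summed up by the limit of > 20000 nM in this assay, at which 3 of the 3 values shown sit. The next compound, compound 4 `Nc1nc(NC2CCCC2)c2ncn(/C=C3/CC3(CO)CO)c2n1`, differs from compound 2 by a single change, (cyclopentyl in place of cyclopropyl on a nitrogen on an aromatic ring). The step closest in kind is a step that the two limits leave unreadable from compound 2 to compound 3, where the group on the same nitrogen changed and the two limits left the size unreadable. The other two steps, a step that the two limits leave unreadable from compound 1 to compound 2 and a step that the two limits leave unreadable from compound 1 to compound 3, are unreadable for the same reason. Nothing seen so far gives a readable step in this assay, so no step beyond the scatter is expected, and another limit is the likeliest outcome. The expected step from compound 2 to compound 4 is a number no higher from compound 2 to compound 4 (the limit leaves the size open). Compound 4 is estimated at 20000 nM, between 8000 nM and 50000 nM.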

Compound 4, half-maximal cytotoxic concentration: > 20000 nM
Compound 4: a limit, no number; the forecaster's own chance of this, stated with the estimate: 80%; the middle value lies on the limit itself.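

Compound 4 gives only a limit of the assay, so none of its steps to compound 1, compound 2 or compound 3 can be read: the limit of > 20000 nM in this assay, at which 4 of the 4 values shown sit. The compounds shown leave open at what concentration any of them harms the cells in this assay, and whether swapping these groups changes that concentration.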